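Swapping methyl for chloro on the diisopropyl dithiocarbamate

A few compounds are considered here, and "the series" means these few. Any claim that something is new, unique, unknown or untested is made for them only; others in the source may bear on it.

Measured compounds:
compound 1 `O=c1c(CSC(=S)N2CCOCC2)coc2cc(Cl)ccc12`: 900 nM
compound 2 `Cc1ccc2c(=O)c(CSC(=S)N(C(C)C)C(C)C)coc2c1`: 700 nM
compound 3 `Cc1ccc2c(=O)c(CSC(=S)N3CCOCC3)coc2c1`: 4000 nM

In a functional assay on HEp-2 cells (Homo sapiens) for antiproliferative activity, read by MTT assay, with a stated time of 72 h (on this read-out lower numbers stand for stronger inhibition and higher numbers for weaker inhibition), compound 2 gives the lowest of the three numbers; compound 1 sits within the usual scatter of it, while compound 3 lies clearly apart, as a 5.7-fold higher number from compound 2 to compound 3 (0.76 log units; beyond the scatter) shows. Compound 4 `CC(C)N(C(=S)SCc1coc2cc(Cl)ccc2c1=O)C(C)C` differs from compound 2 by chloro in place of methyl on an aromatic carbon. For the measured compounds named here, the one measured step that bears on this change runs the opposite way: a 4.4-fold higher number from compound 1 to compound 3 (0.65 log units; beyond the scatter). Reversing it suggests a lower number for compound 4 than for compound 2. Because a 4.4-fold higher number from compound 1 to compound 3 (0.65 log units; beyond the scatter) was modest, the expected step is a 3.5-fold lower number from compound 2 to compound 4 (0.54 log units; beyond the scatter). Compound 4 is therefore estimated at 200 nM, within a range from 80 nM to 600 nM.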

Compound 4, half-maximal inhibitory concentration: 4200 nM
Compound 4: the middle estimate sits 21-fold (1.32 log units) below what was measured, outside the stated range (above it).
By their numbers in this assay, from the lowest: compounds 2 and 1 (each within the scatter of the next); then compounds 3 and 4 (each within the scatter of the next).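

In this assay, chloro in place of methyl on this aromatic carbon has no single fixed outcome: next to diisopropylamino it gives a 6.0-fold higher number from compound 2 to compound 4 (0.78 log units; beyond the scatter), while with morpholin-4-yl the number moves the opposite way: the same change on two cores in this assay, a 4.4-fold higher number (0.65 log units; beyond the scatter) from compound 1 to compound 3 and a 6.0-fold lower number (0.78 log units; beyond the scatter) from compound 4 to compound 2, 27-fold (1.43 log units) apart, beyond the scatter of two such steps

Seen from the other site, diisopropylamino in place of morpholin-4-yl gives a 4.7-fold higher number from compound 1 to compound 4 (0.67 log units; beyond the scatter) on the chloro-bearing core, again reversing what the methyl-bearing pair shows: the same change on two cores in this assay, a 5.7-fold higher number (0.76 log units; beyond the scatter) from compound 2 to compound 3 and a 4.7-fold lower number (0.67 log units; beyond the scatter) from compound 4 to compound 1, 27-fold (1.43 log units) apart, beyond the scatter of two such steps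

So the outcome of a change at either site depends on the group at the other. From the compounds shown here alone, whether this holds for other aromatic substituents, such as fluoro or methoxy, or for another amine, such as diethylamino, stays open.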